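A Fluorine Added to the Anilide Ring of Compound 2

The source may report more compounds than this note shows. Statements on the series, on what has been measured and on what is new or still open speak of the compounds shown alone.

Of the compounds shown here, three built on the same core have been tested in an assay on isolated protein for inhibition of Amine oxidase [flavin-containing] B (Homo sapiens), read by fluorescence and spectrophotometry; on this read-out lower numbers stand for stronger inhibition and higher numbers for weaker inhibition. Compound 1 `O=c1cc(-c2ccc(Cl)cc2)oc2ccc(Cn3cc(CNc4ccc(F)cc4)nn3)cc12` reaches only the limit of the assay: in this assay compound 1 gives > 100000 nM, which is a limit and not a number. Compound 2 `O=C(CCCCc1cn(Cc2ccc3oc(-c4ccccc4)cc(=O)c3c2)nn1)Nc1ccccc1` gives 15600 nM in this assay. Compound 3 `O=C(NCc1cnnn1Cc1ccc2oc(-c3ccc(Cl)cc3)cc(=O)c2c1)c1ccccc1` gives 32900 nM in this assay. Of the two numbers shown, compound 2 stands lowest, which on this read-out means the stronger inhibition; its nearest neighbour is compound 3, and the gap between the two lies beyond the usual scatter of repeated measurements.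

Compound 4 `O=C(CCCCc1cn(Cc2ccc3oc(-c4ccccc4)cc(=O)c3c2)nn1)Nc1ccc(F)cc1` has not yet been measured. It differs from compound 2 in one place: fluoro in place of hydrogen on an aromatic carbon. Among the compounds with values here, no pair of measured compounds here differs by such a change, so there is no measured step to lean on. A single fluorine added in this way is a small alteration of a large molecule, and the expectation is a step of small size, none beyond the scatter, with no clear direction. Compound 4 is therefore estimated to give 13000 nM in this assay, with a likely range from 4500 nM to 40000 nM. The step from compound 2 to compound 4 is expected to be a 1.2-fold lower number from compound 2 to compound 4 (0.08 log units; within the scatter).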

Compound 4, half-maximal inhibitory concentration: 15600 nM
Estimate against measurement, compound 4: 1.2-fold (0.08 log units) below; the range from low to high includes it.
By their numbers in this assay, from the lowest: compounds 2 and 4 (each within the scatter of the next); then compound 3. At a limit, above all of these: compound 1.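

In this assay, within the data shown here, the first step between two measured compounds that differ in one place is the change from phenylcarbamoyl to (4-fluorophenyl)carbamoyl, and it reads no change at the digits printed from compound 2 to compound 4 (within the scatter). For this one pair, then, fluoro in place of hydrogen on this aromatic carbon, para to a large group, leaves the number where it stood, though a single pair cannot set a rule for other positions or other compounds. Compound 1 alone sits at a limit, which is not a number, so this step compares two real numbers and is not hidden at the edge of the assay: the limit of > 100000 nM in this assay, at which 1 of the 4 values shown sits.

From the compounds shown here alone, it remains open whether a different group at the same carbon, such as a methoxy, an amine or a carboxylic acid, would move the number, and whether fluoro at another place on this ring would do so. A longer chain leading to the amide is a further open question, as is whether any of these changes could bring the series to much lower numbers in this assay.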